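A few compounds are considered here, and "the series" means these few. Any claim that something is new, unique, unknown or untested is made for them only; others in the source may bear on it.

Compound 1 `CC(=O)C1=C(C)NC(=O)NC1c1ccoc1`: 6%
Compound 2 `CC1=C(C(=O)NC(C)C)C(c2ccco2)NC(=O)N1`: 3%

Of the compounds shown here, two have been measured in an assay on membranes from CHO cells for displacement of a labelled ligand from adenosine receptor A1 (Homo sapiens), read by scintillation counting, with a stated time of 60 min, tested at 1 uM; a lower number here means less inhibition, a higher number more inhibition at the concentration tested (going by the name of the read-out). In this assay compound 1 gives 6% and compound 2 gives 3%. Compound 2 stands at the lowest of the two numbers, but its nearest neighbour, compound 1, lies within the scatter of it, so the two cannot be ordered. Compound 3 `CC1=C(C(=O)NC(C)C)C(c2ccoc2)NC(=O)N1` differs from compound 2 by furan-3-yl in place of furan-2-yl on a saturated ring carbon. Among the measured compounds shown here, no step between measured compounds exists for this change, and both measured numbers sit close to the floor of the read-out, so no step beyond the scatter is expected in this assay. Compound 3 is expected to give 5%, in the range 0% to 15%. The expected step is a number 2 percentage points higher from compound 2 to compound 3 (within the scatter), within the scatter.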

Compound 3, a percentage reported as inhibition, at one concentration (the size of the read-out at that concentration, not a potency): 1%
For compound 3 the middle estimate is 4 percentage points above the measured one, and the stated range covers the measured number.
By their numbers in this assay, from the lowest: compounds 3, 2 and 1 (each within the scatter of the next).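

In this assay, furan-3-yl in place of furan-2-yl on a saturated ring carbon gives a number 2 percentage points lower from compound 2 to compound 3 (within the scatter) and so does not separate the two furans at this position. With furan-3-yl held in place, isopropylamino in place of methyl on a carbonyl carbon gives a number 5 percentage points lower from compound 1 to compound 3 (within the scatter) and likewise leaves no readable difference. No independent measurement bears on this result. On these data alone, whether a phenyl or thiophene ring on that ring carbon, or a longer chain on the carbonyl carbon, would give a step beyond the scatter remains open.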